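Notes on the tert-butyl replacement for cyclohexyl

This account rests on a few compounds, and the source may have more. Where it says the series, first, only, none or still open, it means among the compounds named here.

Measured in a functional assay on HT-29 cells (Homo sapiens) for inhibition, read by sulforhodamine B assay, with a stated time of 48 h; a lower number here means a stronger inhibitor of growth, a higher number a weaker inhibitor of growth:
- compound 1 `c1ccc2cc(NC3=NCCO3)ccc2c1`: 2000 nM
- compound 2 `c1cc(C2CCCCC2)ccc1NC1=NCCO1`: 12800 nM
- compound 3 `c1ccc(Oc2ccc(NC3=NCCO3)cc2)cc1`: 2000 nM

Compound 2 has the highest of the three numbers in this assay, at 12800 nM. Compound 1 and compound 3 share a lower number, and the gap from compound 2 to each lies beyond the usual scatter.

The next compound to be measured is compound 4 `CC(C)(C)c1ccc(NC2=NCCO2)cc1`. It carries tert-butyl in place of cyclohexyl on an aromatic carbon, and it otherwise matches compound 2: tert-butyl in place of cyclohexyl on an aromatic carbon. Among the compounds with values here, no measured pair in this small set differs in one place only, so there is no direct precedent for the size of this step. The expectation rests on the three values alone. Compound 2 at 12800 nM sits apart from compound 1 at 2000 nM and compound 3 at 2000 nM, which suggests a move toward a lower number rather than no change. A move of moderate size is expected, with some chance that it stays within the scatter.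

The expected change is a 2.8-fold lower number from compound 2 to compound 4 (0.45 log units; beyond the scatter). The estimated value for compound 4 is 4500 nM, with an expected range of 1800 nM to 13000 nM.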

Compound 4, concentration for 50% growth inhibition: 1500 nM
Estimate against measurement, compound 4: 3.0-fold (0.48 log units) above; measured number below the stated range.
By their numbers in this assay, from the lowest: compounds 4, 1 and 3 (each within the scatter of the next); then compound 2.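

In this assay, within the data shown here, the first step that changes one place only gives an 8.5-fold lower number from compound 2 to compound 4 (0.93 log units; beyond the scatter) on replacing cyclohexyl with tert-butyl, so the group on this aromatic carbon clearly affects the read-out. With compound 4 at 1500 nM against compound 2 at 12800 nM, the six-membered non-aromatic ring of carbon only is not needed at this position for growth inhibition in these cells, and the open-chain tert-butyl, with 4 heavy atoms rather than 6, gives the lower number. No measurement in hand accounts for the size of this step.

A single step cannot separate the loss of the ring from the loss of heavy atoms, so an open-chain group of 6 carbon atoms such as n-hexyl, or a smaller one such as methyl, would be needed to tell these apart. Going by these compounds, it also remains open whether a group that is not all carbon, such as an amine or a carboxylic acid, would hold the lower number at this position on the aromatic ring.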